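From 3-Methylbenzyl to 4-Fluorobenzyl: An Expected Limit

This account rests on a few compounds, and the source may have more. Where it says the series, first, only, none or still open, it means among the compounds named here.

Compound 2 `Cc1cccc(Cn2cc(CCCCC[C@@H]3SC[C@@H]4NC(=O)N[C@@H]43)nn2)c1` and compound 1 `Nc1ccccc1Cn1cc(CCCCC[C@@H]2SC[C@@H]3NC(=O)N[C@@H]32)nn1` share one core and differ only at a saturated chain carbon bound to an aromatic nitrogen. In an assay on isolated protein for inhibition of biotin--protein ligase (Homo sapiens), read by scintillation counting, with a stated time of 10 min (on this read-out higher numbers stand for weaker inhibition and lower numbers for stronger inhibition), compound 1 gives > 16000 nM, which is a limit of the assay rather than a number. In this assay compound 2 likewise gives > 16000 nM, again a limit. The step that the two limits leave unreadable from compound 1 to compound 2 cannot be read, since both values sit at the limit of > 16000 nM in this assay, at which 2 of the 2 values shown sit. Compound 3 `O=C1N[C@H]2[C@H](CS[C@H]2CCCCCc2cn(Cc3ccc(F)cc3)nn2)N1` carries the change (4-fluorophenyl in place of 3-methylphenyl on a saturated chain carbon bound to an aromatic nitrogen). Within the data shown here, no measured step bears on it: the one step recorded here is unreadable, and nothing shows that exchanging the group on this phenyl moves the inhibition constant. The expectation is thus that compound 3 stays at the limit, with an expected step that the limit leaves unreadable from compound 2 to compound 3 of no readable size. Compound 3 is estimated at 20000 nM, with a range from 8000 nM to 80000 nM.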

Compound 3, inhibition constant: > 16000 nM
Compound 3: a limit, no number; the forecaster's own chance of this, stated with the estimate: 80%; the middle value does not contradict the limit.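

No step can be read among compound 1, compound 2 and compound 3, because all of them share one limit rather than a number: the limit of > 16000 nM in this assay, at which 3 of the 3 values shown sit.

The compounds shown leave open how strongly each one inhibits, and whether exchanging these phenyl groups changes the inhibition constant at all.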